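The compounds below may be only part of what the source reports. "The series", "measured", "known", "first", "only" and "open" are said of these compounds alone.

Measured compounds:
compound 1 `Cc1ccc2nc(-c3ccccc3N(C)C)[nH]c(=O)c2c1` — in an assay on isolated protein for inhibition of DNA topoisomerase 1 (Homo sapiens), with a stated time of 30 min, tested at 20 uM (a higher number here means a stronger effect of the compound at the concentration tested, a lower number a weaker effect), compound 1 gives 21.1%
compound 2 `Cc1ccc2nc(-c3ccccc3C(F)(F)F)[nH]c(=O)c2c1` — compound 2 gives 21.1%
compound 3 `Cc1ccc2nc(-c3ccccc3C)[nH]c(=O)c2c1` — compound 3 gives "not determined" (no result reported)

The shared core carries a phenyl group with one substituent: dimethylamino in compound 1, trifluoromethyl in compound 2, methyl in compound 3. Compound 3 therefore stands nowhere on the numbers shown; it has no value of its own, and its position can only be inferred from its neighbours. Among the measured compounds shown here, the single measured step, no change at the digits printed from compound 1 to compound 2 (within the scatter), exchanges one group at the same place and leaves the read-out where it was. Compound 4 `Cc1ccc2nc(-c3ccccc3F)[nH]c(=O)c2c1` is the next member and differs from compound 3 as follows: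

fluoro in place of methyl on an aromatic carbon

For the measured compounds named here, the one step that bears on this exchange, no change at the digits printed from compound 1 to compound 2 (within the scatter), moved nothing beyond the scatter, and compounds 1 and 2 sit at the same level. No direction can be read for the methyl-to-fluoro exchange; the expectation is a read-out of the same order as compounds 1 and 2, with wide uncertainty because compound 3 itself contributes no number. Compound 4 is expected to give about 21% in this assay, with the expected range running from 8% to 36%.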

Compound 4, a percentage reported as inhibition, at one concentration (the size of the read-out at that concentration, not a potency): 36.3%
The estimate for compound 4 lay 15.3 percentage points below the measured number; the measured number lies above the stated range.
By their numbers in this assay, from the lowest: compounds 1 and 2 (each within the scatter of the next); then compound 4.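

In this assay the exchange to fluoro gives a number 15.2 percentage points higher from compound 2 to compound 4 (beyond the scatter) when trifluoromethyl leaves and a number 15.2 percentage points higher from compound 1 to compound 4 (beyond the scatter) when dimethylamino leaves, so the first difference beyond the scatter appears at this aromatic carbon. The read-out therefore does depend on the group carried here, which could not be seen from no change at the digits printed from compound 1 to compound 2 (within the scatter) alone. Nothing measured in this set accounts for the higher number.

As far as these compounds go, compound 3 carries no number, and the steps to it cannot be read, so the direct exchange of methyl for fluoro stays open. Also open, from the compounds shown here alone, is whether the higher read-out belongs to fluoro alone or extends to other groups on this aromatic carbon, with chloro, methoxy or a primary amine as the next comparisons.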